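Swapping the Aryl Group on a Thiocarbonyl-Linked Nitrogen

The source may hold more compounds than are shown below. What is called first, only, known or untested is meant among the compounds shown, and "the series" means these compounds.

Compound 1 `OC(c1ccccc1)(c1ccccc1)C1CCN(C(=S)Nc2ccc(OC(F)(F)F)cc2)CC1` is measured in a functional assay for antagonist activity at Neuropeptide Y receptor type 2 (Homo sapiens) (a lower number here means a stronger inhibitor, a higher number a weaker inhibitor), and gives 1050 nM. Among the two compounds measured so far it has the highest number in this assay, meaning it is the weaker inhibitor; its only neighbour, compound 2 `CCN(CC)c1ccc(NC(=S)N2CCC(C(O)(c3ccccc3)c3ccccc3)CC2)cc1`, gives 72 nM in this assay. Within the data shown here, the single step between them, a 15-fold lower number from compound 1 to compound 2 (1.16 log units; beyond the scatter), comes from replacing one group on the aromatic ring, which shows that what sits on this ring strongly shifts the read-out.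

Compound 3 `CCOc1ccc(NC(=S)N2CCC(C(O)(c3ccccc3)c3ccccc3)CC2)c(F)c1` has not yet been measured in this assay. It differs from compound 1 in that same region: 4-ethoxy-2-fluorophenyl in place of 4-(trifluoromethoxy)phenyl on an amide-type nitrogen. Among the measured compounds shown here, the change is not the one seen between compound 1 and compound 2, but it again replaces the trifluoromethoxy-bearing ring, and the large size of a 15-fold lower number from compound 1 to compound 2 (1.16 log units; beyond the scatter) suggests that a replacement here can move the number well beyond the scatter. The direction for an ethoxy group with an added fluorine is not fixed by any measured pair, so the expectation is a more moderate step than that from compound 1 to compound 2.

For compound 3 the expected step is a 3.5-fold lower number from compound 1 to compound 3 (0.54 log units; beyond the scatter), giving an estimated 300 nM in this assay, within a range from 90 nM to 1000 nM.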

Compound 3, half-maximal inhibitory concentration: 1350 nM
Beside the measured number, compound 3's estimate is 4.5-fold (0.65 log units) below it; measured number outside the range, above it.
By their numbers in this assay, from the lowest: compound 2; then compounds 1 and 3 (each within the scatter of the next).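

In this assay, the swap of 4-(trifluoromethoxy)phenyl for 4-ethoxy-2-fluorophenyl on the amide-type nitrogen gives a 1.3-fold higher number from compound 1 to compound 3 (0.11 log units; within the scatter), so compound 1 and compound 3 cannot be told apart in this read-out. This position therefore does not respond to every change of aryl group: two differently substituted rings give matching numbers here. The other comparison gives a 19-fold higher number from compound 2 to compound 3 (1.27 log units; beyond the scatter), which sets 4-(diethylamino)phenyl apart from both other aryl groups and ties the earlier large step to that group, not merely to the loss of 4-(trifluoromethoxy)phenyl, while no supporting data shown here account for this difference.

Going by these compounds, in compound 3 the ethoxy group and the fluorine arrive together, so their separate contributions stay open, and a plain 4-ethoxyphenyl group would be needed to pull them apart. On these data alone, it also remains open whether the low number of compound 2 depends on diethylamino specifically or would persist with a smaller amine such as dimethylamino, a cyclic amine such as piperidine, or a carboxylic acid.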